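Cyclopropyl for dimethylpropyl on the chain: cytotoxicity outlook

A few compounds are considered here, and "the series" means these few. Any claim that something is new, unique, unknown or untested is made for them only; others in the source may bear on it.

Two members of the series have so far been taken through an ADME assay on Huh-7 cells (Homo sapiens) for cytotoxicity, with a stated time of 72 h; a lower number here means that less compound is tolerated, a higher number that more compound is tolerated. Compound 1, `CC(C)CCn1nc(-c2ccn(C)c2)c(O)c(C2=NS(=O)(=O)c3cc(NS(C)(=O)=O)ccc3N2)c1=O`, does not reach a number there: in this assay compound 1 gives > 1000 nM, a limit of the assay. Compound 2, `CCC(C)(C)Cn1nc(-c2cccs2)c(O)c(C2=NS(=O)(=O)c3cc(NS(C)(=O)=O)ccc3N2)c1=O`, is read the same way: in this assay compound 2 gives > 1000 nM, again a limit of the assay. Compound 2 therefore stands where every value shown stands, namely at the limit of > 1000 nM in this assay, at which 2 of the 2 values shown sit, and no ordering between compound 1 and compound 2 can be drawn from this.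

Compound 3, `CS(=O)(=O)Nc1ccc2c(c1)S(=O)(=O)N=C(c1c(O)c(-c3cccs3)nn(CC3(C(F)(F)F)CC3)c1=O)N2`, has not yet been run in this assay. It differs from compound 2 in one place: 1-(trifluoromethyl)cyclopropyl in place of 1,1-dimethylpropyl on a saturated chain carbon bound to an aromatic nitrogen.

For the measured compounds named here, no step between measured compounds exists in this assay, so nothing quantifies what such a change does here. With both measured values resting at the same limit, the working expectation for compound 3 is no shift beyond the usual scatter, and most likely another limit rather than a number. For compound 3 the expected half-maximal cytotoxic concentration is 3000 nM, with a range of 1000 nM to 10000 nM. The step this estimate implies is a step that the limit leaves unreadable from compound 2 to compound 3, expected to be negligible.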

Compound 3, half-maximal cytotoxic concentration: > 1000 nM
Compound 3 ended at the assay's limit; the forecaster's own chance of this, stated with the estimate: 80%; the middle value does not contradict the limit.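

For the compounds shown here, compound 3 rests at the same limit as compound 2 in this assay, so no step from compound 2 to compound 3 can be read: the limit of > 1000 nM in this assay, at which 3 of the 3 values shown sit.

Still open, on these data alone, is where compound 1, compound 2 and compound 3 lie relative to one another past that limit, and whether 1-(trifluoromethyl)cyclopropyl in place of 1,1-dimethylpropyl shifts the half-maximal cytotoxic concentration at all.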